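The compounds below may be only part of what the source reports. "The series", "measured", "known", "first", "only" and "open" are said of these compounds alone.

The two compounds with measured values share the same core. Compound 1 `O=C(O)Cc1sc(CS(=O)(=O)c2ccc(Cl)cc2)nc1-c1ccc(Cl)cc1` is the weaker of the pair: in an in vitro assay on HEK385-7 cells for displacement of a labelled ligand from prostaglandin D2 receptor 2 (Homo sapiens) (on this read-out higher numbers stand for weaker inhibition and lower numbers for stronger inhibition), compound 1 gives 1500 nM. Compound 2 `O=C(O)Cc1sc(C(c2ccc(F)cc2)c2ccc(F)cc2)nc1-c1cccc(F)c1` has the lowest number of the two; in this assay compound 2 gives 1.4 nM, and the gap between the two values lies far beyond the scatter of repeated measurements. Compounds 1 and 2 differ in more than one place, and the two values alone do not tell which part of that difference carries the gain.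

Compound 3 `CS(=O)(=O)Nc1cccc(-c2nc(C(c3ccc(F)cc3)c3ccc(F)cc3)sc2CC(=O)O)c1` is not yet measured. It differs from compound 2 in one place: methanesulfonamido in place of fluoro on an aromatic carbon. Going by the values given here, no measured pair shows this change, so its size has to be guessed; everything else that sets compound 2 apart from compound 1 stays in place. For compound 3 the expected step is a 2.1-fold higher number from compound 2 to compound 3 (0.33 log units; beyond the scatter), a small shift toward weaker inhibition that may well stay within the scatter. The estimate for compound 3 in this assay is 3 nM, with a range from 0.7 nM to 15 nM.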

Compound 3, half-maximal inhibitory concentration: 40 nM
Compound 3: the middle estimate sits 13-fold (1.12 log units) below what was measured, and the stated range ends below it.
By their numbers in this assay, from the lowest: compound 2; then compound 3; then compound 1.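

Replacing the fluoro of compound 2 with methanesulfonamido weakens binding in this assay, with a 29-fold higher number from compound 2 to compound 3 (1.46 log units; beyond the scatter). Going by these compounds alone, this is the first measured change at this place, and it shows that the group on this aromatic carbon, meta to a large group, strongly affects the read-out even when the rest of compound 2 stays the same. The swap adds heavy atoms, a hydrogen-bond donor and hydrogen-bond acceptors all at once, and no measurement available here accounts for the rise in the number.

Which part of the methanesulfonamido group goes with the loss remains open, since this single pair cannot separate its parts; an amine or an acetamido group on the same carbon would give further pairs for comparison with compound 2 and compound 3. Also open, on these data alone, is how a small group such as chloro or methoxy would compare with the fluoro of compound 2, and so whether any replacement on this carbon can keep a number as low as that of compound 2.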